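A few compounds are considered here, and "the series" means these few. Any claim that something is new, unique, unknown or untested is made for them only; others in the source may bear on it.

Going by the values given here, in a functional assay on HepG2 cells (Homo sapiens) for antiproliferative activity, read by MTT assay, with a stated time of 72 h (a lower number here means a stronger inhibitor, a higher number a weaker inhibitor), compound 1 `O=C(N/N=C/c1ccc(Br)cc1)Nc1ccc(Oc2ccnc3[nH]ccc23)cc1` gives 1000 nM and compound 2 `O=C(N/N=C/c1ccc(F)cc1)Nc1ccc(Oc2ccnc3[nH]ccc23)cc1` gives 3430 nM as the higher of the two numbers so far. Compound 3 `O=C(N/N=C/c1cccc(Cl)c1Cl)Nc1ccc(Oc2ccnc3[nH]ccc23)cc1` differs from compound 2 by 2,3-dichlorophenyl in place of 4-fluorophenyl on a carbon with a double bond to nitrogen with 2,3-dichlorophenyl in place of 4-fluorophenyl on a carbon with a double bond to nitrogen. Among the compounds with values here, one measured step bears on this, the modest 3.4-fold higher number from compound 1 to compound 2 (0.54 log units; beyond the scatter) for fluoro in place of bromo on an aromatic carbon. Read in reverse, it suggests that losing the fluoro group may bring a lower number of similar size in this assay. The expected move is a 2.1-fold lower number from compound 2 to compound 3 (0.33 log units; beyond the scatter) in the direction of a lower number. For compound 3 the estimate is 1600 nM with an expected range from 600 nM to 4200 nM.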

Compound 3, half-maximal inhibitory concentration: "not active" (no number reported)
Compound 3: no number reported; the estimate stays without a comparison.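

Going by these compounds alone, compound 3 is reported as not active without a number, so no step from compound 2 to compound 3 can be read. No evidence on this result is available. On these data alone, how 2,3-dichlorophenyl compares numerically with 4-fluorophenyl remains open.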